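Stability notes: from compound 2 to compound 4

The source may hold more compounds than are shown below. What is called first, only, known or untested is meant among the compounds shown, and "the series" means these compounds.

In an ADME assay on microsomes from liver (Homo sapiens) for metabolic stability, with a stated time of 10 min (on this read-out higher numbers stand for a more stable compound and lower numbers for a less stable compound), compound 1 `O=C(O)C1CCC(O)(C(=O)N2CC[C@](c3ccc(C(F)(C(F)(F)F)C(F)(F)F)cc3)(S(=O)(=O)c3ccc(F)cc3)C2)CC1` gives 100%; 95% (2 entries) and compound 3 `CS(=O)(=O)C1CCC(C(=O)N2CC[C@](c3ccc(C(F)(C(F)(F)F)C(F)(F)F)cc3)(S(=O)(=O)c3ccc(F)cc3)C2)CC1` gives 88%; 100% (2 entries), values within the scatter of each other. Compound 2 `O=C(O)C12CCC(C(=O)N3CC[C@](c4ccc(C(F)(C(F)(F)F)C(F)(F)F)cc4)(S(=O)(=O)c4ccc(F)cc4)C3)(CC1)C2` has no single number in this assay: its entry reads "not determined" (no result reported). Compound 4 `O=C(C1CCS(=O)(=O)CC1)N1CC[C@](c2ccc(C(F)(C(F)(F)F)C(F)(F)F)cc2)(S(=O)(=O)c2ccc(F)cc2)C1` differs from it by a group of 8 heavy atoms (5 carbon, 2 oxygen, 1 sulfur; one six-membered non-aromatic ring with 1 hetero atom) in place of a group of 10 heavy atoms (8 carbon, 2 oxygen; 2 five-membered non-aromatic rings of carbon only), on a carbonyl carbon, with 1,1-dioxothian-4-yl now on the carbonyl carbon. For the measured compounds named here, without a number for compound 2, no step can be sized from it. Compound 4 is expected to lie within the scatter of the measured compounds, an expectation resting on compound 1 at 100%; 95% (2 entries) and compound 3 at 88%; 100% (2 entries). For compound 4 the estimated value is 92%, with an expected range of 77% to 100%.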

Compound 4, percent of the compound remaining: 93%
Compound 4: middle estimate off by 1 percentage points, on the low side; the measured number falls inside the stated range.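

For the compounds shown here, compound 2 has no single number in this assay, so no step from it to compound 4 can be read. The compounds shown leave open whether 1,1-dioxothian-4-yl on the carbonyl carbon, replacing the group of compound 2, shifts this read-out at all.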